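Hydroxycarbamoyl in Place of Cyano on the Chain

The compounds below may be only part of what the source reports. "The series", "measured", "known", "first", "only" and "open" are said of these compounds alone.

Compound 1, `C=CCc1cc(C(C)=O)c(O)cc1OCCCCCC#N`: 81%
Compound 2, `CCc1cc(C(C)=O)c(O)cc1OCCCCCCS(C)(=O)=O`: 99%
Compound 3, `CCCc1cc(C(C)=O)c(O)cc1OCCCCCC(=O)O`: 73%

In an assay on isolated protein for inhibition of leukotriene B4 receptor 1 (Homo sapiens), tested at 10 uM (on this read-out lower numbers stand for less inhibition and higher numbers for more inhibition at the one concentration tested (going by the name of the read-out)), compound 1 stands second highest of the three numbers. Its nearest neighbour is compound 3, whose gap to it lies within the usual scatter; the furthest is compound 2, whose gap lies beyond the scatter.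

Compound 4, `C=CCc1cc(C(C)=O)c(O)cc1OCCCCCC(=O)NO`, has not yet been measured. It differs from compound 1 by hydroxycarbamoyl in place of cyano on a saturated chain carbon, five bonds along the chain from an oxygen on an aromatic ring. Going by the values given here, no measured pair shares this change, so nothing in the three values points to a direction. In this assay the step of a number 1 percentage points lower from compound 1 to compound 4 (within the scatter) is expected to be small, not beyond the scatter. Compound 4 is estimated at 80%, with a range from 60% to 95%.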

Compound 4, a percentage reported as inhibition, at one concentration (the size of the read-out at that concentration, not a potency): 85%
Compound 4: middle estimate off by 5 percentage points, on the low side; measured number inside the range.
By their numbers in this assay, from the lowest: compounds 3, 1 and 4 (each within the scatter of the next, the first and the last beyond it); then compound 2.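

In this assay, going by these compounds alone, hydroxycarbamoyl in place of cyano on a saturated chain carbon gives a number 4 percentage points higher from compound 1 to compound 4 (within the scatter) and so supplies the first comparison of compounds that differ in one place. On the core of compound 1, this position therefore accepts either group without a shift beyond the usual scatter. Nothing measured here speaks to why the two groups read alike.

On these data alone, whether an amine or a primary amide in the same place would also read alike remains open. So does whether this change would give a similar step on a longer chain.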